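The source may hold more compounds than are shown below. What is called first, only, known or untested is meant among the compounds shown, and "the series" means these compounds.

Three compounds on a shared core have been run in a functional assay on HeLa cells (Homo sapiens) for inhibition, read by CCK-8 assay, with a stated time of 48 h; on this read-out lower numbers stand for stronger inhibition and higher numbers for weaker inhibition. Compound 1 `COc1cc(-c2ccnc3cc(-c4cn(CO)c5ccccc45)nn23)cc(OC)c1OC` gives 103 nM. Compound 2 `COc1cc(-c2ccnc3cc(-c4cn(C)c5ccccc45)nn23)cc(OC)c1OC` gives 399 nM, and the step of a 3.9-fold higher number from compound 1 to compound 2 (0.59 log units; beyond the scatter) separates the two. Compound 3 `COc1cc(-c2ccnc3cc(-c4ccc(N(C)C)cc4)nn23)cc(OC)c1OC` gives 378 nM, with a 1.1-fold lower number from compound 2 to compound 3 (0.02 log units; within the scatter). Among these three numbers compound 3 stands second highest, nearest to compound 2 within the scatter and furthest from compound 1, beyond it.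

Compound 4 `COc1cc(-c2ccnc3cc(-c4ccc(C(C)(C)C)cc4)nn23)cc(OC)c1OC` awaits measurement. The change from compound 3 is tert-butyl in place of dimethylamino on an aromatic carbon. Within the data shown here, no measured step repeats this change. The step of a 1.1-fold lower number from compound 2 to compound 3 (0.02 log units; within the scatter) shows that exchanging the whole group on that aromatic carbon left the number within the scatter, while the step of a 3.9-fold higher number from compound 1 to compound 2 (0.59 log units; beyond the scatter) concerns a different part of the core and does not bear on it. One group without a ring replacing another on an aromatic carbon, with no such swap measured, leaves the expectation in this assay at no step beyond the scatter: a 1.2-fold higher number from compound 3 to compound 4 (0.08 log units; within the scatter). Compound 4 is therefore estimated at 450 nM, in a range from 180 nM to 1200 nM.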

Compound 4, half-maximal inhibitory concentration: > 10000 nM
Compound 4 ended at the assay's limit (the forecaster's own chance of this, stated with the estimate: 5%); middle value at least 22-fold (1.34 log units) away from the limit.
By their numbers in this assay, from the lowest: compound 1; then compounds 3 and 2 (each within the scatter of the next). At a limit, above all of these: compound 4.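

The position on the aromatic carbon tolerates some exchanges but not all. Replacing the whole 1-methyl-1H-indol-3-yl group with 4-(dimethylamino)phenyl gave a 1.1-fold lower number from compound 2 to compound 3 (0.02 log units; within the scatter), whereas the smaller exchange of dimethylamino for tert-butyl gives an at least 26-fold higher number from compound 3 to compound 4 (1.42 log units; beyond the scatter), and the change to 4-(tert-butyl)phenyl gives an at least 25-fold higher number from compound 2 to compound 4 (1.39 log units; beyond the scatter). So the near-equal numbers of the earlier pair do not extend to every group at this place, and a swap of one acyclic group for another can carry a large step. Compound 4 stands at a limit of the assay, not at a number: the limit of > 10000 nM in this assay, at which 1 of the 4 values shown sits.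

One pair cannot show which difference between dimethylamino and tert-butyl carries the step. On these data alone, a methoxy group, a primary amine or a morpholine on the same aromatic carbon, para to a large group, remains open, as does how far any activity returns with such groups.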